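A few compounds are considered here, and "the series" means these few. Any claim that something is new, unique, unknown or untested is made for them only; others in the source may bear on it.

Measured compounds:
compound 1 `COC(=O)C(C)c1ccc(-c2ccc(C(=O)/C=C/c3ccc(CN4CCCC4)c(O)c3)cc2)c(F)c1`, 430 nM
compound 2 `COC(=O)C(C)c1ccc(-c2ccc(C(=O)/C=C/c3ccc(CN4CCN(C)CC4)c(O)c3)cc2)c(F)c1`, 430 nM

Compound 2 `COC(=O)C(C)c1ccc(-c2ccc(C(=O)/C=C/c3ccc(CN4CCN(C)CC4)c(O)c3)cc2)c(F)c1` stands level with compound 1 in an assay on isolated protein for inhibition of Amine oxidase [flavin-containing] B (Homo sapiens), read by fluorescence, with a stated time of 30 min; on this read-out higher numbers stand for weaker inhibition and lower numbers for stronger inhibition: the step of no change at the digits printed from compound 1 to compound 2 (within the scatter) lies within the scatter. That step is the only measured one in this set, and it exchanged one saturated cyclic amine for another on a saturated chain carbon bound to an aromatic carbon without moving the read-out.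

Compound 3 `COC(=O)C(C)c1ccc(-c2ccc(C(=O)/C=C/c3ccc(CN(C)C)c(O)c3)cc2)c(F)c1` is not yet measured. Compared with compound 2 the change is dimethylamino in place of 4-methylpiperazin-1-yl on a saturated chain carbon bound to an aromatic carbon. Going by the values given here, the one step that bears on it, the step of no change at the digits printed from compound 1 to compound 2 (within the scatter), showed no change at this position, so no more than scatter is expected for compound 3 either, in either direction, since no measured step here ranks one amine above another. The estimated step for compound 3 is no change at the digits printed from compound 2 to compound 3 (within the scatter). Compound 3 is therefore expected to give about 430 nM in this assay, within a range from 200 nM to 950 nM.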

Compound 3, half-maximal inhibitory concentration: 430 nM
The estimate for compound 3 equals the measured number at the digits printed; measured number inside the range.
By their numbers in this assay, from the lowest: compounds 1, 2 and 3 (each within the scatter of the next).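

In this assay, dimethylamino in place of 4-methylpiperazin-1-yl on a saturated chain carbon bound to an aromatic carbon gives no change at the digits printed from compound 2 to compound 3 (within the scatter), and dimethylamino in place of pyrrolidin-1-yl at the same place gives no change at the digits printed from compound 1 to compound 3 (within the scatter). The earlier step only exchanged one ring for another, whereas these steps show that the read-out also holds when the group has no ring, even as the group shrinks from 7 heavy atoms to 3 in the step from the 4-methylpiperazin-1-yl group. Nothing available accounts for this flat result.

As far as these compounds go, all three groups at this place contain a nitrogen bearing no hydrogen, so a primary amine, a carboxylic acid or a simple hydroxyl remains open there. Whether the read-out would still hold with such a group, or with a longer chain carrying the amine, cannot be told from these compounds.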